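This account rests on a few compounds, and the source may have more. Where it says the series, first, only, none or still open, it means among the compounds named here.

In a functional assay on HL-60 cells (Homo sapiens) for antiproliferative activity, read by sulforhodamine B assay, with a stated time of 72 h (a lower number here means a stronger inhibitor, a higher number a weaker inhibitor), two compounds sharing one core have been measured so far. Compound 1 (`Cc1ccccc1NC(=S)N/N=C/c1ccc2ccccc2n1`) gives 73200 nM, and compound 2 (`S=C(N/N=C/c1ccc2ccccc2n1)Nc1ccc(Br)cc1`) gives 27500 nM, the lower of the two numbers. Still unmeasured is compound 3 (`Fc1cccc(NC(=S)N/N=C/c2ccc3ccccc3n2)c1`), which keeps the shared core and differs from compound 2 in one group: 3-fluorophenyl in place of 4-bromophenyl on an amide-type nitrogen. Here 3-fluorophenyl stands in place of 4-bromophenyl on an amide-type nitrogen whose other neighbour is the thiocarbonyl carbon.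

Within the data shown here, only one measured step bears on this change, and it lies at the same place: a 2.7-fold lower number from compound 1 to compound 2 (0.43 log units; beyond the scatter). This modest step, beyond the scatter, puts 4-bromophenyl in place of 2-methylphenyl. Among the measured compounds shown here, no measured compound carries 3-fluorophenyl, so the direction cannot be fixed firmly. Compound 2 holds the lower of just two values, and a step of similar modest size towards a higher number is expected in this assay. The estimated step is a 1.5-fold higher number from compound 2 to compound 3 (0.18 log units; within the scatter). For compound 3 the estimated value is 42000 nM, with an expected range from 15000 nM to 100000 nM.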

Compound 3, half-maximal inhibitory concentration: 43800 nM
The estimate for compound 3 lay 1.0-fold (0.02 log units) below the measured number; the range from low to high includes it.
By their numbers in this assay, from the lowest: compounds 2, 3 and 1 (each within the scatter of the next, the first and the last beyond it).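

In this assay the move from 4-bromophenyl to 3-fluorophenyl on the amide-type nitrogen gives a 1.6-fold higher number from compound 2 to compound 3 (0.20 log units; within the scatter) and so does not separate the two groups, even though the halogen is exchanged while the heavy-atom count stays the same. The comparison with the third aryl group gives a 1.7-fold lower number from compound 1 to compound 3 (0.22 log units; within the scatter) and so does not separate 3-fluorophenyl from 2-methylphenyl either, which leaves compound 3 unresolved from both neighbours, although the earlier step between compound 1 and compound 2 lay beyond the scatter. Nothing available here accounts for these numbers, as no supporting evidence bears on the result.

Since the halogen and its place on the ring change together from compound 2 to compound 3, these compounds cannot show whether either change alone matters in this series. From the compounds shown here alone, it also remains open how the shared core would respond if an amine, a carboxylic acid or a longer chain stood on this nitrogen in place of the substituted phenyl ring.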